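Chloro for bromo on a second oxindole-bearing core

The compounds below may be only part of what the source reports. "The series", "measured", "known", "first", "only" and "open" are said of these compounds alone.

The study compares four compounds that share a fused ring system bearing a halogen and differ in the pyrazoline part. Compound 1 `COc1ccc(C2=NN(C3=NC(=O)/C(=C4\C(=O)Nc5ccc(Br)cc54)S3)C(c3ccc(Cl)cc3)C2)cc1` and compound 2 `COc1ccc(C2=NN(C3=NC(=O)/C(=C4\C(=O)Nc5ccc(Cl)cc54)S3)C(c3ccc(Cl)cc3)C2)cc1` carry one core; compound 3 `CN(C)c1ccc(C2CC(c3ccccc3)=NN2C2=NC(=O)/C(=C3\C(=O)Nc4ccc(Br)cc43)S2)cc1` and compound 4 `CN(C)c1ccc(C2CC(c3ccccc3)=NN2C2=NC(=O)/C(=C3\C(=O)Nc4ccc(Cl)cc43)S2)cc1` carry another, and the difference between the two cores is not broken down here. In a functional assay on cells (Cancer cell lines, Homo sapiens) for cytotoxicity, read by sulforhodamine B assay, with a stated time of 48 h (a lower number here means a stronger inhibitor of growth, a higher number a weaker inhibitor of growth), compound 1 gives 1480 nM, compound 2 gives 430 nM and compound 3 gives 450 nM. The change from compound 1 to compound 2 is chloro in place of bromo on an aromatic carbon, and it made a 3.4-fold lower number from compound 1 to compound 2 (0.54 log units; beyond the scatter). The same change, (chloro in place of bromo on an aromatic carbon), leads from compound 3 to compound 4 on the other core. Compound 4 has not yet been measured in this assay. Since the step from compound 1 to compound 2 was a 3.4-fold lower number from compound 1 to compound 2 (0.54 log units; beyond the scatter), and compound 3 sits at 450 nM, close to compound 2, the author expects a step of similar size, a 3.0-fold lower number from compound 3 to compound 4 (0.48 log units; beyond the scatter), while allowing that a single earlier step on a different core is a thin basis. Compound 4 is therefore estimated at 150 nM, most likely between 60 nM and 450 nM.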

Compound 4, concentration for total growth inhibition: 430 nM
Compound 4: middle estimate off by 2.9-fold (0.46 log units), on the low side, within the range that was stated.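

On the core of compound 3, chloro in place of bromo on an aromatic carbon gave a 1.0-fold lower number from compound 3 to compound 4 (0.02 log units; within the scatter) in this assay, so the change brought no measurable gain there. The step seen on the first core therefore did not carry over to the second, and the two steps differ by more than repeated measurement would explain: the same change on two cores in this assay, a 3.4-fold lower number (0.54 log units; beyond the scatter) from compound 1 to compound 2 and a 1.0-fold lower number (0.02 log units; within the scatter) from compound 3 to compound 4, 3.3-fold (0.52 log units) apart, beyond the scatter of two such steps. Within the data shown here, this shows that, in this series, the result of the swap on one core cannot be assumed for another, but it does not show why, since the two cores differ in several places at once and only two matched pairs are available, so no single part of the pyrazoline can be held responsible.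

The compounds shown leave open how a fluoro group or a plain hydrogen at the same place would behave on either core. They also leave open whether the step returns when only the dimethylamino group of compound 3 is replaced by a methoxy group or a chloro group.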